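A few compounds are considered here, and "the series" means these few. Any claim that something is new, unique, unknown or untested is made for them only; others in the source may bear on it.

Measured compounds:
compound 1 `Cc1ccc([C@@H](C)Oc2cc3onc(CCC(=O)O)c3cc2Cl)nc1` — 1.59 nM
compound 2 `CCc1cc2oc(=O)n(CCC(=O)O)c2cc1Cl` — 316 nM

Within the data shown here, in an assay on HEK293 cells for inhibition of kynurenine 3-monooxygenase (Homo sapiens), read by LC-MS, with a stated time of 20 h (a lower number here means a stronger inhibitor, a higher number a weaker inhibitor), compound 2 gives 316 nM, the highest of the two numbers known so far. Compound 1, the only other one, sits at 1.59 nM, far below that, a gap well beyond the scatter. Among the measured compounds shown here, the two share no single-point difference, so no counted step between them is available.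

Compound 3 `COc1cc2oc(=O)n(CCC(=O)O)c2cc1Cl` is not yet measured. It differs from compound 2 by methoxy in place of ethyl on an aromatic carbon, a like-sized swap with one added acceptor. For the measured compounds named here, no comparable step exists in this set to lean on. A small move is expected for compound 3, no more than the scatter, with the number estimated at 400 nM within 130 nM to 1300 nM; that is, a step of a 1.3-fold higher number from compound 2 to compound 3 (0.10 log units; within the scatter) is expected.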

Compound 3, half-maximal inhibitory concentration: 5010 nM
Beside the measured number, compound 3's estimate is 13-fold (1.10 log units) below it; measured number above the stated range.
By their numbers in this assay, from the lowest: compound 1; then compound 2; then compound 3.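

In this assay methoxy in place of ethyl gives a 16-fold higher number from compound 2 to compound 3 (1.20 log units; beyond the scatter) and so this aromatic carbon, ortho to a chloro group, does not treat two groups of equal heavy-atom count as interchangeable. The change swaps one carbon for oxygen and adds one hydrogen-bond acceptor, and that alone separates the pair. Nothing measured here explains the size of this step.

A methyl, a hydroxyl or a propyl chain on the same carbon would show whether the oxygen or the chain matters more. On these data alone, whether methoxy has the same effect on the core of compound 1 remains open.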